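Paw Edema Inhibition in Three Thiazolo-Fused Amides

The compounds below may be only part of what the source reports. "The series", "measured", "known", "first", "only" and "open" are said of these compounds alone.

Compound 1 `CC1=C(C(=O)Nc2ccc(F)cc2)C(c2ccc([N+](=O)[O-])cc2)n2c(s/c(=C/c3ccc(Cl)cc3Cl)c2=O)=N1` gives 17%. Compound 2 `CC1=C(C(=O)Nc2ccc(F)cc2)C(c2ccc([N+](=O)[O-])cc2)n2c(s/c(=C/c3ccccc3Cl)c2=O)=N1` gives 19%. Compound 3 `CC1=C(C(=O)Nc2ccc(F)cc2)C(c2ccc(Cl)cc2)n2c(s/c(=C/c3ccccc3Cl)c2=O)=N1` gives 16%.

All three were examined in a functional assay on the whole organism (strain albino) for inhibition, with Rattus norvegicus as the target, read by paw edema, with stated times of 1 h and 3 h, at a dose of 25 mg/kg by the oral route; a lower number here means less inhibition, a higher number more inhibition at the dose given (going by the name of the read-out). The three numbers lie close together, and none of the differences between them is larger than the scatter of this kind of measurement. From compound 2 to compound 1 the change is chloro in place of hydrogen on an aromatic carbon, and this gave a number 2 percentage points lower from compound 2 to compound 1 (within the scatter). The cores of compound 2 and compound 3 differ by chloro in place of nitro on an aromatic carbon, and this gave a number 3 percentage points lower from compound 2 to compound 3 (within the scatter). So neither the added chloro group on the benzylidene ring nor the exchange of nitro for chloro on the other aryl ring moved the read-out by an amount that can be told apart from noise.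

Compound 4 `CC1=C(C(=O)Nc2ccc(F)cc2)C(c2ccc(Cl)cc2)n2c(s/c(=C/c3ccc(Cl)cc3Cl)c2=O)=N1` has not yet been measured in this assay. Within the data shown here, it differs from compound 3 by chloro in place of hydrogen on an aromatic carbon, which is the same change as the one from compound 2 to compound 1. On the basis of that earlier step, a number 2 percentage points lower from compound 2 to compound 1 (within the scatter), the expected step is a number 2 percentage points lower from compound 3 to compound 4 (within the scatter), that is, essentially no movement beyond the scatter. Compound 4 is therefore estimated to give 14% in this assay, with a likely range from 6% to 24%.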

Compound 4, a percentage reported as inhibition, in the whole organism at one dose (the size of the read-out at that dose, not a potency): 14%
For compound 4 middle estimate and measured number coincide at the digits printed, and the stated range covers the measured number.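

In this assay, chloro in place of hydrogen on the benzylidene ring, 2-chlorophenyl to 2,4-dichlorophenyl, gave a number 2 percentage points lower from compound 3 to compound 4 (within the scatter), and beside the earlier step the result reads: the same change on two cores in this assay, a number 2 percentage points lower (within the scatter) from compound 2 to compound 1 and a number 2 percentage points lower (within the scatter) from compound 3 to compound 4, 0 percentage points apart, within the scatter of two such steps. Chloro in place of nitro on the other aryl ring gave a number 3 percentage points lower from compound 1 to compound 4 (within the scatter), and this step likewise matches its earlier counterpart: the same change on two cores in this assay, a number 3 percentage points lower (within the scatter) from compound 2 to compound 3 and a number 3 percentage points lower (within the scatter) from compound 1 to compound 4, 0 percentage points apart, within the scatter of two such steps. Among these compounds, each change therefore gave the same reading on both cores, with no sign that the core altered its outcome, but every step lies within the scatter, so this agreement shows only that neither change had a detectable effect on these cores, not that a real effect carries from one core to another.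

Going by these compounds, the four compounds share the fluorophenyl amide and the methyl group on the core, and their aryl rings carry only chloro or nitro groups, so it remains open whether an amine or a carboxylic acid on those rings would shift the read-out beyond the scatter. Also open, on these data alone, is whether a change at the amide, such as a longer chain in place of the fluorophenyl group, would do so, and whether any such step would carry across cores.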